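Swapping the Sulfonyl Aryl Group on a Fixed Core

A few compounds are considered here, and "the series" means these few. Any claim that something is new, unique, unknown or untested is made for them only; others in the source may bear on it.

Measured so far:
compound 1, `CC1CCN(c2c(S(=O)(=O)c3cc(F)cc(F)c3)cnc3cc(Cl)ccc23)CC1`, 94%
compound 2, `CC1CCN(c2c(S(=O)(=O)c3ccc(F)c(Cl)c3)cnc3c(F)cccc23)CC1`, 95%

Two compounds have been characterised in an assay on isolated protein for displacement of a labelled ligand from metabotropic glutamate receptor 5 (Homo sapiens), with a stated time of 60 min, tested at 1 uM; a higher number here means more inhibition at the concentration tested (going by the name of the read-out), a lower number less inhibition. Compound 1 gives 94%, and compound 2 gives 95%. The two numbers sit within the usual scatter of one another, so no order between compound 1 and compound 2 can be read from them; both are high.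

Compound 3, `Cc1ccc(S(=O)(=O)c2cnc3cc(Cl)ccc3c2N2CCC(C)CC2)cc1C`, has not yet been measured in this assay. It differs from compound 1 in one place: 3,4-dimethylphenyl in place of 3,5-difluorophenyl on a sulfonyl sulfur. Going by the values given here, no measured pair shows what this kind of change does on this core, so there is no basis for expecting a large step in either direction; the expectation rests only on the high values of compound 1 and compound 2.

The estimate for compound 3 in this assay is 86%, with a range from 55% to 98%. That estimate means an expected step of a number 8 percentage points lower from compound 1 to compound 3 (within the scatter), which is expected to stay within the scatter.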

Compound 3, a percentage reported as inhibition, at one concentration (the size of the read-out at that concentration, not a potency): 86%
For compound 3 middle estimate and measured number coincide at the digits printed; low and high end bracket the measured number.
By their numbers in this assay, from the lowest: compounds 3, 1 and 2 (each within the scatter of the next).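

In this assay, going by these compounds alone, the replacement of 3,5-difluorophenyl by 3,4-dimethylphenyl on a sulfonyl sulfur gives the first comparison on the shared core that differs in one place: a number 8 percentage points lower from compound 1 to compound 3 (within the scatter). This single pair shows that the fluorine atoms of compound 1 are not needed for a high reading at the concentration tested, since compound 3, with only carbon on its aryl group, gives 86%. Nothing available explains how the two aryl groups compare in this assay.

The compounds shown leave open whether an aryl group carrying an amine or a carboxylic acid would keep the reading high at this position. Readings at one concentration are also not potencies, so any difference in potency between compound 1 and compound 3 remains unresolved.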